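The source may report more compounds than this note shows. Statements on the series, on what has been measured and on what is new or still open speak of the compounds shown alone.

Measured so far:
compound 1 `O=c1[nH]cc(S(=O)(=O)Nc2ccccc2-c2cn(-c3ccccc3)nn2)c(=O)[nH]1` — 10600 nM
compound 2 `Cc1cccc(-n2cc(-c3ccccc3NS(=O)(=O)c3c[nH]c(=O)[nH]c3=O)nn2)c1` — 21900 nM
compound 3 `O=c1[nH]cc(S(=O)(=O)Nc2cccc(-c3cn(-c4ccccc4)nn3)c2)c(=O)[nH]1` — > 100000 nM

Series notes. Compound 1 is read in an ADME assay on L02 cells (Homo sapiens) for cytotoxicity, read by MTT assay, with a stated time of 24 h (a higher number here means that more compound is tolerated, a lower number that less compound is tolerated), and gives 10600 nM. Compound 2 gives 21900 nM in this assay, and the step of a 2.1-fold higher number from compound 1 to compound 2 (0.32 log units; beyond the scatter) shows a methyl on an aromatic carbon adding a modest amount to the tolerated concentration. Compound 3 stands apart from both: in this assay compound 3 gives > 100000 nM, which is a limit of the assay and not a number, so only a bound is known for it (the limit of > 100000 nM in this assay, at which 1 of the 3 values shown sits).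

Compound 4 `Cc1ccc(-n2cc(-c3cccc(NS(=O)(=O)c4c[nH]c(=O)[nH]c4=O)c3)nn2)cc1` is not yet measured. It differs from compound 3 by methyl in place of hydrogen on an aromatic carbon. Among the compounds with values here, the one measured step that bears on this change is a 2.1-fold higher number from compound 1 to compound 2 (0.32 log units; beyond the scatter), which moved in the direction of a higher number and only modestly. Since compound 3 already sits at the limit, a modest shift upward, or none beyond the scatter, would leave compound 4 at or past that limit as well, so a limit rather than a number is the likely outcome in this assay. Compound 4 is therefore expected to give about 200000 nM, within 70000 nM to 600000 nM, which means an expected step that the limit leaves unreadable from compound 3 to compound 4.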

Compound 4, half-maximal cytotoxic concentration: 23100 nM
Compound 4: middle estimate off by 8.7-fold (0.94 log units), on the high side; the measured number lies below the stated range.
By their numbers in this assay, from the lowest: compound 1; then compounds 2 and 4 (each within the scatter of the next). At a limit, above all of these: compound 3.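

In this assay, within the data shown here, the change from phenyl to 4-methylphenyl gives an at least 4.3-fold lower number from compound 3 to compound 4 (0.63 log units; beyond the scatter), so on this core the methyl goes with less compound being tolerated, the opposite direction to the only earlier methyl step. The change therefore does not carry the same sign from one core to the other among the compounds shown: the same change on two cores in this assay, a 2.1-fold higher number (0.32 log units; beyond the scatter) from compound 1 to compound 2 and an at least 4.3-fold lower number (0.63 log units; beyond the scatter) from compound 3 to compound 4, at least 8.9-fold (0.95 log units) apart, beyond the scatter of two such steps For compound 3, the value > 100000 nM is a limit of the assay and not a number, so the step from it is known only as a bound: the limit of > 100000 nM in this assay, at which 1 of the 4 values shown sits.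

The compounds shown carry only hydrogen or methyl at this place on the aromatic ring, so it remains open whether a methoxy group, a chlorine atom or a carboxylic acid on the same carbon would lower the number in the same way, or whether the drop is specific to methyl. Going by these compounds, it also remains open how the core of compound 1 would respond to a 4-methylphenyl group, which would show whether the opposite signs of the two steps follow the core alone.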